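The source may hold more compounds than are shown below. What is called first, only, known or untested is meant among the compounds shown, and "the series" means these compounds.

Measured compounds:

compound 1, `CC(C(=O)NCc1ccc(C(C)(C)C)nc1N1CCCC1)c1ccc(NS(C)(=O)=O)c(F)c1`: 1.2 nM
compound 2, `COCCCOc1nc(C(C)(C)C)ccc1CNC(=O)C(C)c1ccc(NS(C)(=O)=O)c(F)c1`: 5.6 nM
compound 3, `CC(C(=O)NCc1ccc(C(C)(C)C)nc1OCc1ccccc1)c1ccc(NS(C)(=O)=O)c(F)c1`: 4.4 nM

All three values come from an assay on cells for antagonist activity at transient receptor potential cation channel subfamily V member 1 (Homo sapiens), read by FLIPR and calcium flux, with a stated time of 6 min; a higher number here means a weaker inhibitor, a lower number a stronger inhibitor. Compound 1 gives the lowest number of the three. The step of a 4.7-fold higher number from compound 1 to compound 2 (0.67 log units; beyond the scatter) and the step of a 3.7-fold higher number from compound 1 to compound 3 (0.56 log units; beyond the scatter) both lie beyond the scatter, so compound 1 stands clear of the other two. Compounds 2 and 3 are within the scatter of each other, as a 1.3-fold lower number from compound 2 to compound 3 (0.10 log units; within the scatter) shows.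

Compound 4, `CC(C(=O)NCc1ccc(C(C)(C)C)nc1SC1CCCC1)c1ccc(NS(C)(=O)=O)c(F)c1`, is not yet measured in this assay. It differs from compound 1 in one place: cyclopentylsulfanyl in place of pyrrolidin-1-yl on an aromatic carbon

The two measured steps that bear on this are the ones leaving compound 1, where pyrrolidin-1-yl was replaced on the same aromatic carbon: a 4.7-fold higher number from compound 1 to compound 2 (0.67 log units; beyond the scatter) and a 3.7-fold higher number from compound 1 to compound 3 (0.56 log units; beyond the scatter). Each replacement gave a modest rise in the number. Cyclopentylsulfanyl is a third replacement at that position, and no measured pair covers it directly; the closest comparison is the two oxygen-linked groups, both of which weakened the compound modestly. A step of similar size and direction is therefore expected, a 3.3-fold higher number from compound 1 to compound 4 (0.52 log units; beyond the scatter), with a range wide enough to cover no change beyond the scatter. Compound 4 is estimated at 4 nM, between 1.5 nM and 12 nM.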

Compound 4, inhibition constant: 2.5 nM
Estimate against measurement, compound 4: 1.6-fold (0.20 log units) above; low and high end bracket the measured number.
By their numbers in this assay, from the lowest: compound 1; then compounds 4, 3 and 2 (each within the scatter of the next, the first and the last beyond it).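

In this assay, for the compounds shown here, cyclopentylsulfanyl is the first group at this aromatic carbon next to the ring nitrogen that is joined through sulfur, and pyrrolidin-1-yl still gives the lowest number in the set (a 2.1-fold higher number from compound 1 to compound 4 (0.32 log units; beyond the scatter)), so compound 1 now stands clear of a sulfur-linked replacement as well as the two oxygen-linked ones. The sulfur-linked group also divides those two: it stands clear of 3-methoxypropoxy (a 2.2-fold lower number from compound 2 to compound 4 (0.35 log units; beyond the scatter)) but not of benzyloxy (a 1.8-fold lower number from compound 3 to compound 4 (0.25 log units; within the scatter)), a separation that compounds 2 and 3 alone did not show. No measurement available here accounts for any of these differences.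

The compounds shown do not separate the effect of the sulfur link from that of the cyclopentyl ring, a question that cyclopentyloxy at the same carbon would address in a direct pair with compound 4. Going by these compounds, it also remains open how far the result for compound 1 depends on the pyrrolidine ring itself, rather than on a nitrogen link in general, which piperidin-1-yl or dimethylamino at this carbon would test.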